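Cytotoxicity notes on a salicylanilide series, compound 2 to compound 4

A few compounds are considered here, and "the series" means these few. Any claim that something is new, unique, unknown or untested is made for them only; others in the source may bear on it.

Of the compounds shown here, three of one shared core have been measured in an ADME assay on A549 cells (Homo sapiens) for cytotoxicity, read by resazurin assay, with a stated time of 48 h; on this read-out higher numbers stand for lower toxicity in this test and lower numbers for higher toxicity in this test. Compound 1 `CCCCCCCCC(C)Nc1ccc(NC(=O)c2cc(Cl)ccc2O)c(Cl)c1` gives 21900 nM. Compound 3 `O=C(Nc1ccc(NCc2cc(F)cc(C(F)(F)F)c2)cc1Cl)c1cc(Cl)ccc1O` gives 30900 nM. Compound 2 `O=C(Nc1ccc(NC2CCCCC2)cc1Cl)c1cc(Cl)ccc1O` gives 68300 nM, the highest of the three numbers; its nearest neighbour is compound 3, beyond the scatter, and the furthest is compound 1, also beyond the scatter. On this read-out compound 2 is thus the least toxic of the three in this test.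

Compound 4 `O=C(Nc1ccc(NCc2ccncc2)cc1Cl)c1cc(Cl)ccc1O` is not yet measured. The change from compound 2 to compound 4 is (pyridin-4-yl)methyl in place of cyclohexyl on a nitrogen on an aromatic ring. Among the compounds with values here, no step between measured compounds touches this position, so no direct precedent exists for the size or direction of the change.

The other two substituents at this nitrogen, in compound 1 and compound 3, both give lower numbers than compound 2, yet neither of them resembles the entering group. The expectation for compound 4 is a step of a 1.1-fold higher number from compound 2 to compound 4 (0.04 log units; within the scatter) from compound 2, a change that is expected to stay within the scatter. Compound 4 is therefore estimated at 75000 nM, with a range from 30000 nM to 180000 nM.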

Compound 4, half-maximal cytotoxic concentration: 65300 nM
Beside the measured number, compound 4's estimate is 1.1-fold (0.06 log units) above it, within the range that was stated.
By their numbers in this assay, from the lowest: compounds 1 and 3 (each within the scatter of the next); then compounds 4 and 2 (each within the scatter of the next).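

In this assay, within the data shown here, this is the first step that can be read directly at this nitrogen: a 1.0-fold lower number from compound 2 to compound 4 (0.02 log units; within the scatter), with (pyridin-4-yl)methyl in place of cyclohexyl on a nitrogen on an aromatic ring. The earlier compounds shown here showed only that two other substituents here came with lower numbers than compound 2; this pair shows that a six-membered non-aromatic ring of carbon only can give way to a six-membered aromatic ring with one hetero atom, together with the added hydrogen-bond acceptor, without a change that stands out from the scatter. No measurement at hand bears on why these two compounds read alike.

The compounds shown leave open whether the ring nitrogen of compound 4 matters here, since compound 3, at 30900 nM, carries a substituted benzyl group and compound 4, at 65300 nM, a pyridine-bearing one, and the plain benzyl group that would link them does not appear among them. Also open, on these data alone, is whether a saturated amine in the ring, as in (piperidin-4-yl)methyl, would read the same in this assay.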